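This account rests on a few compounds, and the source may have more. Where it says the series, first, only, none or still open, it means among the compounds named here.

Measured so far:
compound 1, `Nc1nc2ccc(OCC(F)(F)C(F)(F)F)cc2s1`: 7.5 mg/kg
compound 2, `Nc1nc2cc(OC(F)(F)F)ccc2s1`: > 10 mg/kg
compound 3, `Cn1c(=N)sc2cc(OC(F)(F)F)ccc21`: 5 mg/kg

All three share a core and were tested in a functional assay on the whole organism with Rattus norvegicus as the target; a lower number here means that less compound is needed, a higher number that more compound is needed for the effect. Compound 3 gives 5 mg/kg and compound 1 gives 7.5 mg/kg; these two numbers sit within the usual scatter of each other, so neither can be called the better of the pair. For compound 2 the result is only a limit, > 10 mg/kg, which means no number was reached; this is the limit of > 10 mg/kg in this assay, at which 1 of the 3 values shown sits.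

The next compound, compound 4, `CS(=O)(=O)CCn1c(=N)sc2cc(OC(F)(F)F)ccc21`, is built from compound 3 by one change: (methylsulfonyl)methyl in place of hydrogen on a saturated chain carbon bound to an aromatic nitrogen. This lengthens the chain that hangs from the ring nitrogen, from a methyl to a 2-(methylsulfonyl)ethyl group.

Within the data shown here, no measured pair differs in just this way, so nothing among the numbers shows what the change does. The closest guide is simply that compound 3 itself gives 5 mg/kg. The expectation is that compound 4 stays close to compound 3, with the step of a 1.2-fold higher number from compound 3 to compound 4 (0.08 log units; within the scatter) estimated to lie within the scatter or only slightly beyond it. Compound 4 is therefore expected to give about 6 mg/kg in this assay, somewhere between 2.5 mg/kg and 15 mg/kg.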

Compound 4, dose for half-maximal effect: 1.8 mg/kg
The estimate for compound 4 lay 3.3-fold (0.52 log units) above the measured number; the whole stated range lies above it.
By their numbers in this assay, from the lowest: compound 4; then compounds 3 and 1 (each within the scatter of the next). At a limit, above all of these: compound 2.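

In this assay, going from methyl to 2-(methylsulfonyl)ethyl on the aromatic nitrogen gives a 2.8-fold lower number from compound 3 to compound 4 (0.44 log units; beyond the scatter) and so less compound is needed for the effect. This is the first pair among the compounds shown that differs in one place, and it shows that this position accepts a substantially larger group, here with sulfur and oxygen atoms, while the effect is not only kept but reached at a lower dose. The data at hand give no information on why the number falls.

This single step cannot tell whether the methylsulfonyl group itself matters or whether a longer chain alone would do the same, and a plain propyl chain would be the group that could separate the two. Also open is how this assay would read for an amine or a carboxylic acid at the end of the chain, for a chain longer than 2-(methylsulfonyl)ethyl, or for the same chain on the other compounds shown.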